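The source may report more compounds than this note shows. Statements on the series, on what has been measured and on what is new or still open speak of the compounds shown alone.

Measured compounds:
- compound 1 `Cc1cn([C@@H]2O[C@H](CO[Si](C)(C)C(C)(C)C)[C@@]3(OS(=O)(=O)C=C3NC(=O)c3ccccc3)[C@H]2O[Si](C)(C)C(C)(C)C)c(=O)n(C)c1=O`: 4900 nM
- compound 2 `Cc1cn([C@@H]2O[C@H](CO[Si](C)(C)C(C)(C)C)[C@@]3(OS(=O)(=O)C=C3NC(N)=O)[C@H]2O[Si](C)(C)C(C)(C)C)c(=O)n(C)c1=O`: 3700 nM
- compound 3 `COC(=O)CNC1=CS(=O)(=O)O[C@@]12[C@@H](CO[Si](C)(C)C(C)(C)C)O[C@@H](n1cc(C)c(=O)n(C)c1=O)[C@@H]2O[Si](C)(C)C(C)(C)C`: 105000 nM

In a functional assay on MT4 cells (Homo sapiens) (a lower number here means that less compound is tolerated, a higher number that more compound is tolerated), compound 3 stands highest of the three, so it is the best tolerated. The step of a 21-fold higher number from compound 1 to compound 3 (1.33 log units; beyond the scatter) and the step of a 28-fold higher number from compound 2 to compound 3 (1.45 log units; beyond the scatter) both show that replacing an acyl-type group on the amine nitrogen with (methoxycarbonyl)methyl raised the number by a large margin; the step of a 1.3-fold lower number from compound 1 to compound 2 (0.12 log units; within the scatter) between the two acyl-type compounds stays within the scatter.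

Compound 4 `C=C(C)C(=O)NC(=O)NC1=CS(=O)(=O)O[C@@]12[C@@H](CO[Si](C)(C)C(C)(C)C)O[C@@H](n1cc(C)c(=O)n(C)c1=O)[C@@H]2O[Si](C)(C)C(C)(C)C` differs from compound 3 at that same nitrogen: ((1-methylethenyl)carbonyl)carbamoyl in place of (methoxycarbonyl)methyl on an amine nitrogen. Here the (methoxycarbonyl)methyl group leaves again and a carbamoyl-containing group enters, so compound 4 resembles compound 2 at this point more than compound 3. The two large steps that ended at compound 3 bear on this change in reverse, and a large drop is therefore expected, roughly back toward the values of compound 1 and compound 2. Compound 4 is expected to sit near 9000 nM, with a range from 3000 nM to 30000 nM, which means an estimated step of a 12-fold lower number from compound 3 to compound 4 (1.07 log units; beyond the scatter).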

Compound 4, half-maximal cytotoxic concentration: 1190 nM
The estimate for compound 4 lay 7.6-fold (0.88 log units) above the measured number; the whole stated range lies above it.
By their numbers in this assay, from the lowest: compound 4; then compounds 2 and 1 (each within the scatter of the next); then compound 3.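

In this assay, putting ((1-methylethenyl)carbonyl)carbamoyl in place of (methoxycarbonyl)methyl on the amine nitrogen gives an 88-fold lower number from compound 3 to compound 4 (1.95 log units; beyond the scatter), so this change does not simply return the number to the level of the two earlier acyl-type compounds. Putting (1-methylethenyl)carbonyl in place of hydrogen on the amide-type nitrogen gives a 3.1-fold lower number from compound 2 to compound 4 (0.49 log units; beyond the scatter), and ((1-methylethenyl)carbonyl)amino in place of phenyl on the carbonyl carbon gives a 4.1-fold lower number from compound 1 to compound 4 (0.61 log units; beyond the scatter), so acyl-type groups at this position can differ beyond the scatter, which the benzoyl and carbamoyl pair did not show. Nothing available here explains why the number moves at this position.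

Still open, going by these compounds, is whether the high number of compound 3 depends on its methyl ester, which a carboxylic acid in its place would test. Also open, on these data alone, is whether the low number of compound 4 depends on the carbon-carbon double bond, which an isopropyl group in place of 1-methylethenyl would test.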